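Swapping the sulfonyl ethyl for an amino group

The compounds below may be only part of what the source reports. "The series", "measured", "known", "first", "only" and "open" are said of these compounds alone.

The series shares one core, carrying a methylpiperidinyl and a trifluoromethyl group on a pyridine linked through an amide to a phenyl bearing a sulfonamide. Compound 1 `CC1CCN(c2nc(C(F)(F)F)ccc2CNC(=O)C(C)c2ccc(NS(C)(=O)=O)cc2)CC1` gives 1.2 nM in an assay on cells for antagonist activity at transient receptor potential cation channel subfamily V member 1 (Homo sapiens), read by FLIPR and calcium flux, with a stated time of 15 min; on this read-out higher numbers stand for weaker inhibition and lower numbers for stronger inhibition. Compound 2 `Cc1cc(C(C)C(=O)NCc2ccc(C(F)(F)F)nc2N2CCC(C)CC2)ccc1NS(C)(=O)=O` gives 0.6 nM; the step of a 2.0-fold lower number from compound 1 to compound 2 (0.30 log units; within the scatter) is within the scatter, so the two read alike. Compound 3 `CCS(=O)(=O)Nc1ccc(C(C)C(=O)NCc2ccc(C(F)(F)F)nc2N2CCC(C)CC2)cc1F` gives 4.4 nM, the highest number of the three and beyond the scatter from both compound 1 and compound 2.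

Compound 4 `CC1CCN(c2nc(C(F)(F)F)ccc2CNC(=O)C(C)c2ccc(NS(N)(=O)=O)c(F)c2)CC1` departs from compound 3 by a single change: amino in place of ethyl on a sulfonyl sulfur. Compound 4 therefore keeps the fluorine of compound 3 on the phenyl ring and differs only in what sits on the sulfonyl sulfur. Among the compounds with values here, no measured step touches this position: the only step recorded, from compound 1 to compound 2, concerns a methyl on an aromatic carbon and says nothing about the sulfonyl substituent. The range spanned by the three compounds is modest, and nothing in it argues for a large move in either direction. Compound 4 is therefore expected near compound 3, with the step of a 1.1-fold higher number from compound 3 to compound 4 (0.06 log units; within the scatter) expected to stay within the scatter, giving an estimated 5 nM with a range from 1.5 nM to 16 nM.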

Compound 4, inhibition constant: 2.7 nM
The estimate for compound 4 lay 1.9-fold (0.27 log units) above the measured number, within the range that was stated.
By their numbers in this assay, from the lowest: compounds 2 and 1 (each within the scatter of the next); then compounds 4 and 3 (each within the scatter of the next).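

In this assay, exchanging ethyl for amino on the sulfonyl sulfur, with the sulfonamide nitrogen as its other neighbour, gives a 1.6-fold lower number from compound 3 to compound 4 (0.21 log units; within the scatter), so the two compounds read alike. Within the data shown here, this is the first reading at this position: the earlier step concerned a methyl on an aromatic carbon, whereas here ethylsulfonyl becomes sulfamoyl, with a single nitrogen and its hydrogen-bond donor entering where two carbons leave, and the number does not move beyond the scatter. The result thus shows that, on the fluorine-bearing phenyl ring shared by this pair, the sulfur accepts either an ethyl or an amino group with no change that can be told apart in this read-out, though no measurement shown here offers an explanation for this result.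

From the compounds shown here alone, a longer chain such as propyl, or a larger nitrogen group such as dimethylamino, on the same sulfur remains open, so the limits of this position are unknown. Going by these compounds, it also remains open whether the amino group would read the same way on the phenyl rings of compound 1 and compound 2, which carry no fluorine.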